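The compounds below may be only part of what the source reports. "The series", "measured", "known", "first", "only" and "open" are said of these compounds alone.

Measured in an assay on isolated protein for binding affinity to adenosine receptor A1 (Bos taurus); a higher number here means a weaker inhibitor, a lower number a stronger inhibitor:
- compound 1, `CCCCCCNc1nc(-c2ccccc2)nc2c1nnn2Cc1ccccc1`: 13200000 nM
- compound 2, `COc1ccc(C(=O)Nc2nc(-c3ccccc3)nc3c2nnn3Cc2ccccc2F)cc1`: 21900000 nM
- compound 3, `FC(F)(F)c1ccccc1Cn1nnc2c(NC3CCCC3)nc(-c3ccccc3)nc21`: 600000 nM

Compound 2 carries the highest number of the three in this assay. Its gap to compound 1 is within the scatter, so no order between compound 2 and compound 1 can be read from these two numbers. Going by the values given here, compound 3 stands clearly lower than compound 2, beyond the scatter, and is the only compound of the three with a number plainly apart from the other two.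

Compound 4, `OCCCNc1nc(-c2ccccc2)nc2c1nnn2Cc1ccccc1F`, has not yet been measured in this assay. It differs from compound 2 in one place: 3-hydroxypropyl in place of (4-methoxyphenyl)carbonyl on a nitrogen on an aromatic ring. Among the compounds with values here, no pair of measured compounds differing in one place is available, so the step has to be judged from the whole set. Compound 1 and compound 3, both bearing an alkylamino group in place of the amide, give numbers at or below that of compound 2; compound 1 sits within the scatter of compound 2, compound 3 well below it. A small downward step is therefore expected from compound 2 to compound 4, of a size a 2.4-fold lower number from compound 2 to compound 4 (0.39 log units; beyond the scatter) that may not exceed the scatter. Compound 4 is estimated at 9000000 nM, with a range from 1500000 nM to 45000000 nM.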

Compound 4, inhibition constant: 3700000 nM
Compound 4: middle estimate off by 2.4-fold (0.39 log units), on the high side; the measured number falls inside the stated range.
By their numbers in this assay, from the lowest: compound 3; then compound 4; then compounds 1 and 2 (each within the scatter of the next).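

Going by these compounds alone, at the nitrogen on an aromatic ring, the first readable change in this assay is 3-hydroxypropyl in place of (4-methoxyphenyl)carbonyl (a 5.9-fold lower number from compound 2 to compound 4 (0.77 log units; beyond the scatter)), a modest step. This position therefore accepts both an acyl group carrying a six-membered aromatic ring and a shorter open chain carrying a hydroxyl, with the lower number on the chain side. The swap alters the carbonyl, the ring and the hydrogen-bond donor count together, and no measurement available here ties the step to any one of them.

A plain propyl or 3-aminopropyl group on this nitrogen, with the rest of compound 4 unchanged, would show whether the hydroxyl counts in the step. A benzyl group there would separate the carbonyl from the aromatic ring, and a longer hydroxyalkyl chain would test chain length.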